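Replacing methoxy with trifluoromethyl on the cinnamate ring

This account rests on a few compounds, and the source may have more. Where it says the series, first, only, none or still open, it means among the compounds named here.

Compound 2, `COc1ccccc1/C=C/C(=O)OC/C=C/c1cc(OC)c(OC)cc1OC`, is one of three esters tested in a functional assay on the whole organism (strain Kunming) with Mus musculus as the target, with a stated time of 0.5 h, at a dose of 100 mg/kg by the intraperitoneal route; a lower number here means a stronger effect, a higher number a weaker effect of the compound at the dose given. In this assay compound 2 gives 100%. Its two neighbours share this reading: compound 1, `COc1cc(OC)c(OC)cc1/C=C/COC(=O)/C=C/c1ccc(OC)c(OC)c1OC`, gives 100%, and compound 3, `COc1cccc(/C=C/C(=O)OC/C=C/c2cc(OC)c(OC)cc2OC)c1`, gives 100%. Compound 2 therefore stands level with both compounds 1 and 3 at the digits shown, and no compound among the three can be called stronger or weaker than another.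

For the measured compounds named here, the one step between measured compounds that differ in a single place runs no change at the digits printed from compound 2 to compound 3 (within the scatter), where the methoxy moves from the 2-position to the 3-position of the phenyl ring on the cinnamate side.

Compound 4, `COc1cc(OC)c(OC)cc1/C=C/COC(=O)/C=C/c1ccccc1C(F)(F)F`, has not yet been measured. It differs from compound 2 in one place: trifluoromethyl in place of methoxy on an aromatic carbon. Going by the values given here, no measured step replaces a methoxy with a trifluoromethyl, so the only step that bears on it is the move of the methoxy from compound 2 to compound 3, which stayed within the scatter. On that basis the step from compound 2 to compound 4 is expected to be a number 5 percentage points lower from compound 2 to compound 4 (within the scatter), that is, nothing beyond the scatter. Compound 4 is estimated at 95%, with a range from 75% to 100%.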

Compound 4, a percentage reported as activity, at one dose (the size of the read-out at that dose, not a potency): 100%
The estimate for compound 4 lay 5 percentage points below the measured number, within the range that was stated.
By their numbers in this assay, from the lowest: compounds 1, 2, 3 and 4 (each within the scatter of the next).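

In this assay, the step from the 2-methoxyphenyl to the 2-(trifluoromethyl)phenyl ester reads no change at the digits printed from compound 2 to compound 4 (within the scatter). This is the first step among these compounds in which the methoxy on the cinnamate ring is replaced rather than moved, and the trifluoromethyl that enters has more heavy atoms and no hydrogen-bond acceptor, yet the read-out stays level. The step that combines a change of group with a change of place, no change at the digits printed from compound 3 to compound 4 (within the scatter), also stays within the scatter, and nothing measured bears on why the reading holds at this position.

All the compounds shown give the same reading, so it remains open whether any change on this ring can shift the read-out at this dose, and these steps give no measure of how much the position matters. As far as these compounds go, what an amine or a carboxylic acid on this aromatic carbon would do is also open, as is the effect of a longer chain between the ester and the ring.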